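The source may report more compounds than this note shows. Statements on the series, on what has been measured and on what is new or still open speak of the compounds shown alone.

Compound 2 `COCCNC(=O)/C=C/c1cnc(Nc2ccc(C#N)cc2)nc1Oc1c(C)cc(C#N)cc1C` belongs to a small set of three measured compounds that share one core and differ only in what the amide-type nitrogen carries. In an ADME assay on TZM cells (Homo sapiens) for cytotoxicity, with a stated time of 1 days (a higher number here means that more compound is tolerated, a lower number that less compound is tolerated), compound 2 gives > 213 nM, which is a limit of the assay rather than a number. Compound 1 `Cc1cc(C#N)cc(C)c1Oc1nc(Nc2ccc(C#N)cc2)ncc1/C=C/C(N)=O` in this assay gives > 243 nM, again a limit. Compound 3 `Cc1cc(C#N)cc(C)c1Oc1nc(Nc2ccc(C#N)cc2)ncc1/C=C/C(=O)NC1CCN(S(C)(=O)=O)CC1` in this assay gives > 175 nM, also a limit. As a result the steps a step that the two limits leave unreadable from compound 1 to compound 2, a step that the two limits leave unreadable from compound 1 to compound 3 and a step that the two limits leave unreadable from compound 2 to compound 3 cannot be read in size or direction.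

Compound 4 `Cc1cc(C#N)cc(C)c1Oc1nc(Nc2ccc(C#N)cc2)ncc1/C=C/C(=O)N1CCN(C=O)CC1` has not yet been measured. It differs from compound 2 in one place: 4-formylpiperazin-1-yl in place of (2-methoxyethyl)amino on a carbonyl carbon. The measured steps that bear on this change are the three just named, all of which exchange the group on the amide-type nitrogen, but every value sits at a limit, as the limit of > 175 nM in this assay, at which 1 of the 3 values shown sits, the limit of > 213 nM in this assay, at which 1 of the 3 values shown sits, and the limit of > 243 nM in this assay, at which 1 of the 3 values shown sits, show, so no size and no direction is available from them. The step that the limit leaves unreadable from compound 2 to compound 4 is therefore expected to be none beyond the scatter, most likely ending at a limit once more. Compound 4 is expected to give 250 nM, with a range from 150 nM to 600 nM.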

Compound 4, half-maximal cytotoxic concentration: > 197 nM
Compound 4: a limit, no number (the forecaster's own chance of this, stated with the estimate: 85%); the middle value lies beyond the limit too.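

In this assay compound 4 gives > 197 nM as a limit of the assay and not a number, so its steps from compound 1, compound 2 and compound 3 cannot be read in size or direction. The compounds shown leave open whether the group on the carbonyl carbon changes cytotoxicity at all.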